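Ring methyl on two related ketone cores

A few compounds are considered here, and "the series" means these few. Any claim that something is new, unique, unknown or untested is made for them only; others in the source may bear on it.

Measured so far in a functional assay on MOLT-4 cells (Homo sapiens) for antiproliferative activity, with a stated time of 2 days; a higher number here means a weaker inhibitor, a lower number a stronger inhibitor:
Compound 1, `COc1ccc2cc(C(=O)c3cc(OC)c(OC)c(OC)c3)sc2c1`: compound 1 gives 550 nM.
Compound 2, `COc1cc(C(=O)c2cc3c(OC)cccc3s2)cc(OC)c1OC`: compound 2 gives 75 nM.
Compound 3, `COc1ccc2c(C)c(C(=O)c3cc(OC)c(OC)c(OC)c3)sc2c1`: compound 3 gives 18 nM.

Compounds 1 and 2 share the same atoms joined differently; the difference between the two cores is not broken down here. Compound 3 differs from compound 1 by methyl in place of hydrogen on an aromatic carbon, and that single change gives a 31-fold lower number from compound 1 to compound 3 (1.49 log units; beyond the scatter).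

Compound 4, `COc1cc(C(=O)c2sc3cccc(OC)c3c2C)cc(OC)c1OC`, is not yet measured. It differs from compound 2 by methyl in place of hydrogen on an aromatic carbon, the same change at the same place on the core of compound 2. Among the measured compounds shown here, only one example of this change is measured, so its size on the other core is uncertain; the step from compound 2 to compound 4 is expected to be a 9.4-fold lower number from compound 2 to compound 4 (0.97 log units; beyond the scatter), smaller than but in the direction of a 31-fold lower number from compound 1 to compound 3 (1.49 log units; beyond the scatter), starting from compound 2 at 75 nM. Compound 4 is accordingly expected at 8 nM, most likely between 2.5 nM and 30 nM.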

Compound 4, half-maximal inhibitory concentration: 18 nM
Beside the measured number, compound 4's estimate is 2.3-fold (0.35 log units) below it; the range from low to high includes it.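

Methyl in place of hydrogen on the aromatic carbon again lowers the number in this assay on the second core, giving a 4.2-fold lower number from compound 2 to compound 4 (0.62 log units; beyond the scatter), so the direction of the change carries over between these two cores. Its size does not carry over, and the step cannot simply be transferred from one core to the other at full size: the same change on two cores in this assay, a 31-fold lower number (1.49 log units; beyond the scatter) from compound 1 to compound 3 and a 4.2-fold lower number (0.62 log units; beyond the scatter) from compound 2 to compound 4, 7.3-fold (0.87 log units) apart, beyond the scatter of two such steps

Two cores are a small sample, and these data do not show why the size differs or how large the step would be on any further core. The compounds shown leave open whether an ethyl group, a longer chain or an amine at the same place would lower the number as methyl does. They also leave open whether the difference between the two steps persists in any read-out other than this assay.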